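A few compounds are considered here, and "the series" means these few. Any claim that something is new, unique, unknown or untested is made for them only; others in the source may bear on it.

Measured so far:
- compound 2 `CCC(C(=O)N1CCN(c2cccc(F)c2)CC1)N1C(=O)CCC1=O`, 0%
- compound 3 `CC(C(=O)N1CCN(c2cccc(F)c2)CC1)N1C(=O)CCC1=O`, 0%
- compound 1 `COCC(C(=O)N1CCN(c2cccc(C(F)(F)F)c2)CC1)N1C(=O)CCC1=O`, 50%

In a functional assay on the whole organism (strain Swiss) with Mus musculus as the target, in the maximal electroshock model, with a stated time of 1 h, at a dose of 100 mg/kg by the intraperitoneal route (a lower number here means a weaker effect, a higher number a stronger effect of the compound at the dose given), compound 2 stands level with compound 3, the two together the lowest of the three numbers; compound 1 lies a full step higher, beyond the scatter. Compound 4 `CCC(C(=O)N1CCN(c2cccc(C(F)(F)F)c2)CC1)N1C(=O)CCC1=O` is not yet measured. It differs from compound 2 in one place, (trifluoromethyl in place of fluoro on an aromatic carbon).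

Going by the values given here, the only measured single step, no change at the digits printed from compound 2 to compound 3 (within the scatter), concerns the saturated chain and says nothing about the aromatic substituent. Compound 1 carries the trifluoromethyl group of compound 4 but also a methoxymethyl in place of the ethyl chain, so the gap between compound 1 and compound 2 cannot be assigned to either change alone. Among the compounds with values here, no measured step therefore bears directly on the change from fluoro to trifluoromethyl.

For compound 4 an effect somewhere between compound 2 and compound 1 is expected, estimated at 25% (range 0% to 50%). The expected step is a number 25 percentage points higher from compound 2 to compound 4 (beyond the scatter).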

Compound 4, a percentage reported as activity, at one dose (the size of the read-out at that dose, not a potency): 0%
Estimate against measurement, compound 4: 25 percentage points above; the range from low to high includes it.
By their numbers in this assay, from the lowest: compounds 2, 3 and 4 (each within the scatter of the next); then compound 1.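

In this assay, with the ethyl chain held, trifluoromethyl in place of fluoro on the aromatic carbon gives no change at the digits printed from compound 2 to compound 4 (within the scatter) and so brings no effect at this dose. With trifluoromethyl held, the chain position now has a comparison in one place: methyl in place of methoxy gives a number 50 percentage points lower from compound 1 to compound 4 (beyond the scatter) and the whole effect seen in compound 1 is gone, which ties that effect to the methoxy end of the chain in this trifluoromethyl setting. No measurement at hand explains this loss.

On these data alone, whether the methoxy chain keeps its effect with fluoro on the aromatic carbon stays open. So does whether a hydroxyl, an amine or a longer ether chain at the same position can stand in for methoxy.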